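Amide-tail variation around a shared nitro sulfone core

A few compounds are considered here, and "the series" means these few. Any claim that something is new, unique, unknown or untested is made for them only; others in the source may bear on it.

Compound 2 `CC1CCN(C(=O)CCCNC(=O)c2ccc(S(C)(=O)=O)c([N+](=O)[O-])c2)CC1` in an assay on isolated protein for inhibition of vitamin D3 receptor (Homo sapiens), read by fluorescence polarization (a lower number here means a stronger inhibitor, a higher number a weaker inhibitor), reports only a limit, > 60000 nM. Compound 1 `CN(Cc1cccc(F)c1)C(=O)CCCNC(=O)c1ccc(S(C)(=O)=O)c([N+](=O)[O-])c1` likewise gives a limit in this assay, > 60000 nM. Compound 3 `CS(=O)(=O)c1ccc(C(=O)NCCCC(=O)N2Cc3ccccc3C2)cc1[N+](=O)[O-]` also gives a limit in this assay, > 60000 nM. All three values sit at the limit of > 60000 nM in this assay, at which 3 of the 3 values shown sit, so a step that the two limits leave unreadable from compound 1 to compound 2 and a step that the two limits leave unreadable from compound 1 to compound 3 carry no readable size. Compound 4 `CS(=O)(=O)c1ccc(C(=O)NCCCC(=O)N2CCC(c3ccccc3)CC2)cc1[N+](=O)[O-]` carries phenyl in place of methyl on a saturated ring carbon. The closest measured comparison is a step that the two limits leave unreadable from compound 2 to compound 3, which also alters the group on the carbonyl carbon of compound 2, yet its size is hidden by the two limits. No direction beyond the scatter can therefore be derived. Compound 4 is expected to remain at the limit, estimated at 80000 nM within 20000 nM to 300000 nM, the expected step being a step that the limit leaves unreadable from compound 2 to compound 4.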

Compound 4, half-maximal inhibitory concentration: > 60000 nM
Compound 4: only a limit was reported; the forecaster's own chance of this, stated with the estimate: 85%; the middle value is on the limit's open side.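

The step between compound 2 and compound 4 cannot be read, since both report only limits in this assay: the limit of > 60000 nM in this assay, at which 4 of the 4 values shown sit.
The compounds shown leave open which group on the carbonyl carbon, if any, gives a readable value in this assay.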